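Trimming the amine substituent on the shared core

A few compounds are considered here, and "the series" means these few. Any claim that something is new, unique, unknown or untested is made for them only; others in the source may bear on it.

Compound 3 `CCCNc1nc(-c2ccccc2)nc2c1nnn2Cc1ccccc1` gives 37000000 nM in an assay on isolated protein for binding affinity to adenosine receptor A1 (Bos taurus) (on this read-out lower numbers stand for stronger inhibition and higher numbers for weaker inhibition), and stands highest of the three numbers measured. Compound 1 `O[C@H]1CCCC[C@@H]1Nc1nc(-c2ccccc2)nc2c1nnn2Cc1ccccc1` gives 10300000 nM in this assay, and compound 2 `OC1CCC(Nc2nc(-c3ccccc3)nc3c2nnn3Cc2ccccc2)CC1` gives 2700000 nM. The steps of a 3.6-fold higher number from compound 1 to compound 3 (0.56 log units; beyond the scatter) and a 14-fold higher number from compound 2 to compound 3 (1.14 log units; beyond the scatter) both run toward weaker binding as a hydroxycyclohexyl group is exchanged for propyl. Compound 4 `CNc1nc(-c2ccccc2)nc2c1nnn2Cc1ccccc1` carries hydrogen in place of ethyl on a saturated chain carbon bound to a nitrogen on an aromatic ring. Within the data shown here, no measured step pares the chain itself, so this shortening can only be read against those two steps, which move toward weaker binding when the amine substituent is reduced. For compound 4 a modest step toward a higher number is expected, a 1.6-fold higher number from compound 3 to compound 4 (0.21 log units; within the scatter). Compound 4 is estimated at 60000000 nM, within 20000000 nM to 200000000 nM.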

Compound 4, inhibition constant: 353000000 nM
For compound 4 the middle estimate is 5.9-fold (0.77 log units) below the measured one; the measured number lies above the stated range.
By their numbers in this assay, from the lowest: compound 2; then compound 1; then compound 3; then compound 4.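

Shortening the chain from propyl to methyl on the amine nitrogen, with no ring or hydroxyl involved, still moves the number up in this assay (a 9.5-fold higher number from compound 3 to compound 4 (0.98 log units; beyond the scatter)), so chain length at this position matters on its own. Measured against methyl, the two hydroxycyclohexyl groups show much wider gaps (a 130-fold higher number from compound 2 to compound 4 (2.12 log units; beyond the scatter)) and (a 34-fold higher number from compound 1 to compound 4 (1.53 log units; beyond the scatter)). Across these four compounds, the number rises from either hydroxycyclohexyl to propyl to methyl, and none goes against that order.

On these data alone, whether a longer chain such as hexyl, or a plain cyclohexyl without the hydroxyl, would follow this order remains open. Nothing available explains the size of these steps.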